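A few compounds are considered here, and "the series" means these few. Any claim that something is new, unique, unknown or untested is made for them only; others in the source may bear on it.

Compound 1 `CCC(=O)N1CC2CC(C1)N2` is the starting point of this small set. Going by the values given here, in an assay on SH-EP1 cells for agonist activity at Neuronal acetylcholine receptor; alpha4/beta2 (Homo sapiens), read by FLIPR and calcium flux (a lower number here means a smaller maximal response, a higher number a larger maximal response), compound 1 gives 98%, the highest of the three numbers measured so far. Compound 2 `C[C@@H]1C[C@@H]1C(=O)N1CC2CC(C1)N2` gives 88% in this assay, and compound 3 `C[C@H]1C[C@H]1C(=O)N1CC2CC(C1)N2` gives 87%. The step of a number 10 percentage points lower from compound 1 to compound 2 (within the scatter) and the step of a number 11 percentage points lower from compound 1 to compound 3 (beyond the scatter) describe the same kind of replacement, and between the two products there is only a number 1 percentage points lower from compound 2 to compound 3 (within the scatter). Compound 4 `C[C@@H]1C[C@H]1C(=O)N1CC2CC(C1)N2` carries the change 2-methylcyclopropyl in place of ethyl on a carbonyl carbon relative to compound 1. Both measured steps of this kind bear on it and were small. Compound 4 is therefore expected to give 88% in this assay, with an expected range from 78% to 98%. That would be an expected step of a number 10 percentage points lower from compound 1 to compound 4 (within the scatter), close to what the measured pair showed.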

Compound 4, largest response reached (Emax), in percent of the reference or control that the assay uses: 110%
Compound 4: the middle estimate sits 22 percentage points below what was measured; the measured number lies above the stated range.
By their numbers in this assay, from the lowest: compounds 3, 2 and 1 (each within the scatter of the next, the first and the last beyond it); then compound 4.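

Going by these compounds alone, the change from ethyl to 2-methylcyclopropyl on a carbonyl carbon can raise the response in this assay, with a number 12 percentage points higher from compound 1 to compound 4 (beyond the scatter), which the earlier compounds did not show. Its outcome depends on configuration, with a number 22 percentage points higher from compound 2 to compound 4 (beyond the scatter) and a number 23 percentage points higher from compound 3 to compound 4 (beyond the scatter), although the atoms and bonds stay the same. Each of these two steps involves one stereocentre at a saturated ring carbon, and the structures record this: the fact that one of compounds 3 and 4 is drawn with a defined configuration and the other without, at the place where they differ

As far as these compounds go, what the remaining configuration of the 2-methylcyclopropyl group would give stays open. So does whether unsubstituted cyclopropyl or a longer chain such as butyl on that carbonyl carbon would match compound 4.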